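Alkoxy Replaced by Bromo on the Shared Core

A few compounds are considered here, and "the series" means these few. Any claim that something is new, unique, unknown or untested is made for them only; others in the source may bear on it.

Compound 1, `CC(C)COc1ccc2oc(/C=C/[S+](C)[O-])cc(=O)c2c1`: 5000 nM in a functional assay on DLD-1 cells (Homo sapiens) for cytotoxicity, with a stated time of 48 h; on this read-out higher numbers stand for weaker inhibition and lower numbers for stronger inhibition
Compound 2, `CC(C)CCOc1ccc2oc(/C=C/[S+](C)[O-])cc(=O)c2c1`: 4100 nM

Compound 2 holds the lower of the two numbers, but the step of a 1.2-fold lower number from compound 1 to compound 2 (0.09 log units; within the scatter) lies within the scatter, so no order between the two can be claimed. Compound 3, `C[S+]([O-])/C=C/c1cc(=O)c2cc(Br)ccc2o1`, differs from compound 2 by bromo in place of isopentyloxy on an aromatic carbon. For the measured compounds named here, the single measured step concerns isobutyl in place of isopropyl on a saturated chain carbon, a different kind of change, and gives no guide here. With nothing pointing either way, the step to compound 3 is expected to be small, estimated as a 1.2-fold higher number from compound 2 to compound 3 (0.09 log units; within the scatter). Compound 3 is estimated at 5000 nM, ranging from 1500 nM to 16000 nM.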

Compound 3, half-maximal inhibitory concentration: 4500 nM
For compound 3 the middle estimate is 1.1-fold (0.05 log units) above the measured one; measured number inside the range.
By their numbers in this assay, from the lowest: compounds 2, 3 and 1 (each within the scatter of the next).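

In this assay, replacing the whole alkoxy chain with a single bromine atom on this aromatic carbon gives a 1.1-fold higher number from compound 2 to compound 3 (0.04 log units; within the scatter) and a 1.1-fold lower number from compound 1 to compound 3 (0.05 log units; within the scatter), both within the scatter. The earlier pair varied only the end of the chain, whereas these steps show that the number stays within the scatter without any alkoxy group at this position. Nothing on hand explains this. On these data alone, whether an amine, a carboxylic acid or a plain hydrogen on this aromatic carbon would move the number beyond the scatter remains open.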